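The source may hold more compounds than are shown below. What is called first, only, known or untested is meant among the compounds shown, and "the series" means these compounds.

In an ADME assay on MDCK cells (Canis lupus familiaris) for cytotoxicity, read by MTT assay, with a stated time of 24 h (on this read-out higher numbers stand for lower toxicity in this test and lower numbers for higher toxicity in this test), compound 1 `O=S(=O)(NCc1csc2ccccc12)c1ccc(C(F)(F)F)cc1` gives 94800 nM. Compound 2 `O=S(=O)(NCc1cc2ccccc2s1)c1ccc(F)cc1` stands without a single number, its result being "not determined" (no result reported). Compound 3 `Cc1ccc(S(=O)(=O)NCc2cc3ccccc3s2)cc1` has not yet been measured. The change methyl in place of fluoro on an aromatic carbon places methyl in place of fluoro on an aromatic carbon, para to a large group. For the measured compounds named here, no step between measured compounds exists to size this change, so no step beyond the scatter is expected in this assay, in either direction. Going by the values given here, the only guide is the 94800 nM of compound 1. Compound 3 is estimated at 80000 nM, with an expected range of 30000 nM to 200000 nM.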

Compound 3, half-maximal cytotoxic concentration: > 210000 nM
Compound 3 gave a limit, no number; the forecaster's own chance of this, stated with the estimate: 30%; at least 2.6-fold (0.41 log units) between middle value and limit.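

For the compounds shown here, no step from compound 2 to compound 3 can be read in this assay, as compound 2 has no reported result. Compound 3 gives only a limit, > 210000 nM. As far as these compounds go, what the change from 4-fluorophenyl to 4-methylphenyl does to this read-out stays open.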